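The source may hold more compounds than are shown below. What is called first, only, known or untested is meant among the compounds shown, and "the series" means these compounds.

Measured so far in an assay for inhibition of protein deacetylase HDAC6 (Homo sapiens); a lower number here means a stronger inhibitor, a higher number a weaker inhibitor:
Compound 1, `NS(=O)(=O)NCCCC[C@H](NC(=O)OCc1ccccc1)C(=O)Nc1nccs1`, gives 4100 nM.
Compound 2, `NS(=O)(=O)NCCCC[C@H](NC(=O)OCc1ccccc1)C(=O)Nc1nc2ccccc2s1`, gives 190 nM.
Compound 3, `CCOC(=O)c1csc(NC(=O)[C@H](CCCCNS(N)(=O)=O)NC(=O)OCc2ccccc2)n1`, gives 580 nM.

Compound 3 holds the second highest of the three numbers, nearer to compound 2 than to compound 1. From the shared core of compound 1 the step of a 7.1-fold lower number from compound 1 to compound 3 (0.85 log units; beyond the scatter) was beyond the scatter, the step of a 22-fold lower number from compound 1 to compound 2 (1.33 log units; beyond the scatter) larger still, and the gap between the two substituted compounds was a 3.1-fold higher number from compound 2 to compound 3 (0.48 log units; beyond the scatter).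

Compound 4, `COc1ccc(-c2csc(NC(=O)[C@H](CCCCNS(N)(=O)=O)NC(=O)OCc3ccccc3)n2)cc1`, is not yet measured. It differs from compound 3 in one place: 4-methoxyphenyl in place of ethoxycarbonyl on an aromatic carbon. Among the measured compounds shown here, the steps that bear on this are the two that change the same aromatic carbon of the core, from compound 1 to compound 2 and from compound 1 to compound 3; both lowered the number beyond the scatter, the 1,3-benzothiazol-2-yl change more than the ethoxycarbonyl one. For the measured compounds named here, a 4-methoxyphenyl there has no direct precedent among the three, so the expectation rests on those two steps alone. Compound 4 is expected to give a somewhat lower number than compound 3, an estimated step of a 1.9-fold lower number from compound 3 to compound 4 (0.29 log units; within the scatter). In this assay compound 4 is estimated at 300 nM, range 100 nM to 900 nM.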

Compound 4, half-maximal inhibitory concentration: 200 nM
For compound 4 the middle estimate is 1.5-fold (0.18 log units) above the measured one, within the range that was stated.
By their numbers in this assay, from the lowest: compounds 2 and 4 (each within the scatter of the next); then compound 3; then compound 1.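

In this assay, the aromatic carbon next to the ring nitrogen accepts a substituent bearing a six-membered aromatic ring of carbon only: a 21-fold lower number from compound 1 to compound 4 (1.31 log units; beyond the scatter), and replacing ethoxycarbonyl gives a 2.9-fold lower number from compound 3 to compound 4 (0.46 log units; beyond the scatter). Ethoxycarbonyl is therefore not needed for a lower number at this place, since 4-methoxyphenyl has more heavy atoms and fewer hydrogen-bond acceptors, and its carbonyl is absent. Nothing available gives a cause for either step.

The compounds shown leave open how much of the step belongs to the aromatic ring and how much to the methoxy, which a plain phenyl on the same carbon would separate. They also leave open how a carboxylic acid or an amine at this place would compare with 4-methoxyphenyl.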